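Adding a Third Methoxy Group to Compound 2

This account rests on a few compounds, and the source may have more. Where it says the series, first, only, none or still open, it means among the compounds named here.

Measured so far:
Compound 1 `Cc1cc(O)c(C2=NN(c3ccc(S(N)(=O)=O)cc3)C(c3ccccc3O)C2)cc1Cl` gives 1330 nM in a functional assay on PC-3 cells (Homo sapiens) for antiproliferative activity, with a stated time of 48 h; a higher number here means a weaker inhibitor of growth, a lower number a stronger inhibitor of growth.
Compound 2 `COc1ccc(C2CC(c3cc(Cl)c(C)cc3O)=NN2c2ccc(S(N)(=O)=O)cc2)cc1OC` gives 2610 nM in this assay.

Compound 2 stands at the highest of the two numbers, and its nearest neighbour is compound 1, with a 2.0-fold higher number from compound 1 to compound 2 (0.29 log units; within the scatter). Compound 3 `COc1ccc(C2CC(c3cc(Cl)c(C)cc3O)=NN2c2ccc(S(N)(=O)=O)cc2)c(OC)c1OC` carries the change (methoxy in place of hydrogen on an aromatic carbon), on the same aryl ring where the earlier change took place. For the measured compounds named here, the only step that bears on this is the one from compound 1 to compound 2, which replaced 2-hydroxyphenyl by 3,4-dimethoxyphenyl on the saturated ring carbon, and that step stayed within the scatter. A further methoxy on that ring is therefore expected to give no step beyond the scatter in this assay, in either direction: a 1.0-fold lower number from compound 2 to compound 3 (0.00 log units; within the scatter). For compound 3 the expected value in this assay is 2600 nM, within a range of 1000 nM to 6800 nM.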

Compound 3, concentration for 50% growth inhibition: 2270 nM
Compound 3: the middle estimate sits 1.1-fold (0.06 log units) above what was measured; low and high end bracket the measured number.
By their numbers in this assay, from the lowest: compounds 1, 3 and 2 (each within the scatter of the next).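

In this assay, methoxy in place of hydrogen on this aromatic carbon, ortho to a large group and ortho to a methoxy group, gives a 1.1-fold lower number from compound 2 to compound 3 (0.06 log units; within the scatter), so this position accepts the added group without a step beyond the scatter. The larger change, 2,3,4-trimethoxyphenyl in place of 2-hydroxyphenyl on the saturated ring carbon, gives a 1.7-fold higher number from compound 1 to compound 3 (0.23 log units; within the scatter), so neither of the two aryl groups bearing methoxy groups separates from the 2-hydroxyphenyl compound in this read-out. No other measurement bears on this result, and its reason remains unknown.

The compounds shown leave open whether an amine, a carboxylic acid or a longer chain such as butoxy on this aromatic carbon would also stay within the scatter. They also leave open whether the same holds on cells other than those of this assay.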